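A few compounds are considered here, and "the series" means these few. Any claim that something is new, unique, unknown or untested is made for them only; others in the source may bear on it.

Measured so far in a functional assay on B16-F10 cells (Mus musculus) for antiproliferative activity, read by MTT assay, with a stated time of 48 h (a higher number here means a weaker inhibitor, a lower number a stronger inhibitor), are these compounds
- compound 1 `CCCC(C)Oc1ccc(C(=O)/C=C/c2c(/C=C/c3ccc(OC)cc3)cc(OC)cc2OC)cc1` with 6.7 ug/mL
- compound 2 `CCCCOc1ccc(C(=O)/C=C/c2c(/C=C/c3ccc(OC)cc3)cc(OC)cc2OC)cc1` with 5.3 ug/mL

Compound 2 stands level with compound 1 within the scatter, so neither ranks ahead. Compound 3 `CCCCCCOc1ccc(C(=O)/C=C/c2c(/C=C/c3ccc(OC)cc3)cc(OC)cc2OC)cc1` differs from compound 2 by ethyl in place of hydrogen on a saturated chain carbon, four bonds along the chain from an oxygen on an aromatic ring and has not been measured. For the measured compounds named here, only one measured step bears on this chain: a 1.3-fold lower number from compound 1 to compound 2 (0.10 log units; within the scatter) is small, and it removes a methyl rather than extending the chain. No step beyond the scatter is therefore expected in this assay and no direction can be assigned. The estimated step is a 1.0-fold higher number from compound 2 to compound 3 (0.02 log units; within the scatter) and stays an expectation. For compound 3 the estimated value is 5.5 ug/mL with an expected range of 2.5 ug/mL to 12 ug/mL in this series.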

Compound 3, half-maximal inhibitory concentration: 10.4 ug/mL
The estimate for compound 3 lay 1.9-fold (0.28 log units) below the measured number; low and high end bracket the measured number.
By their numbers in this assay, from the lowest: compounds 2, 1 and 3 (each within the scatter of the next).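

In this assay ethyl in place of hydrogen on this saturated chain carbon, four bonds along the chain from an oxygen on an aromatic ring, gives a 2.0-fold higher number from compound 2 to compound 3 (0.29 log units; within the scatter) and so extends the chain without a step beyond the scatter. Hexyl in place of 1-methylbutyl gives a 1.6-fold higher number from compound 1 to compound 3 (0.19 log units; within the scatter) and likewise separates neither compound, so the three chains remain level. Nothing on hand offers an explanation for these numbers.

From the compounds shown here alone, whether a longer chain such as octyl, or an amine at the chain end, would produce a step beyond the scatter remains open.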